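The source may report more compounds than this note shows. Statements on the series, on what has been measured and on what is new or still open speak of the compounds shown alone.

Compound 1 `CN1CCN(c2cccc3[nH]c(C(=O)c4ccccc4)nc23)CC1` was tested in an assay on HEK293 cells for displacement of a labelled ligand from 5-hydroxytryptamine receptor 7 (Homo sapiens), read by scintillation counting; a lower number here means a stronger inhibitor, a higher number a weaker inhibitor. For compound 1 only a limit was recorded, > 500 nM. Compound 2 `CN1CCN(c2ccc3[nH]c(C(=O)c4ccc5ccccc5c4)nc3c2)CC1` likewise gave only a limit in this assay, > 500 nM. Compound 3 `c1ccc(Cc2nc3c(N4CCNCC4)cccc3[nH]2)cc1` also sits at a limit in this assay, > 500 nM. So compound 3 stands where every measured compound here stands, at the limit of > 500 nM in this assay, at which 3 of the 3 values shown sit, and no measured step separates any two of them. Compound 4 `CN1CCN(c2cccc3[nH]c(Cc4ccccc4)nc23)CC1` differs from compound 3 by methyl in place of hydrogen on an amine nitrogen in a ring. Going by the values given here, no measured pair shows what this change does, so the expected step is none beyond the scatter, a step that the limit leaves unreadable from compound 3 to compound 4. Compound 4 is therefore expected to give 1500 nM in this assay, within 400 nM to 6000 nM, and most likely to be reported again only as a limit.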

Compound 4, inhibition constant: > 500 nM
Compound 4: no number, only a limit; the forecaster's own chance of this, stated with the estimate: 70%; the middle value does not contradict the limit.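

Compound 4 gives only a limit, as do compound 3 and compound 1, so neither step to compound 4 can be read in this assay: the limit of > 500 nM in this assay, at which 4 of the 4 values shown sit.

Going by these compounds, what methyl in place of hydrogen, or benzyl in place of benzoyl, does to the inhibition constant stays open.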